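The compounds below may be only part of what the source reports. "The series", "measured", "known", "first", "only" and "open" are said of these compounds alone.

Compound 2 `Cc1cc(C)c(S(=O)(=O)N2CCC(N3CCC(CCO)CC3)CC2)c(C)c1` stands second highest among the three measured numbers in a functional assay on DLD-1 cells (Homo sapiens) for antiproliferative activity, read by CellTiter-Glo, with a stated time of 72 h; on this read-out higher numbers stand for weaker inhibition and lower numbers for stronger inhibition: compound 2 gives 19 nM, and its nearest neighbour is compound 1 `CC1CCN(C2CCN(S(=O)(=O)c3cccc(-c4ccc(F)cc4)c3)CC2)CC1`, which in this assay gives 12 nM, a pair of values that lie within the scatter of each other. Furthest away is compound 3 `Cc1cc(C)cc(-c2cccc(S(=O)(=O)N3CCC(N4CCC(C)CC4)CC3)c2)c1`, which in this assay gives 41 nM, beyond the scatter from compound 2.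

Compound 4 `Cc1cc(C)c(S(=O)(=O)N2CCC(N3CCCCC3)CC2)c(C)c1` differs from compound 2 in one place: hydrogen in place of 2-hydroxyethyl on a saturated ring carbon

For the measured compounds named here, the only measured single-point step, a 3.4-fold higher number from compound 1 to compound 3 (0.53 log units; beyond the scatter), concerns a change on the aromatic part of the shared core and says nothing direct about the saturated ring terminus. Going by the values given here, no measured pair isolates the 2-hydroxyethyl group, so the data give no direction for this change. Compound 1, which carries a methyl on the corresponding ring carbon, and compound 2 sit within the scatter of each other, although they differ elsewhere too. The step of a 1.3-fold higher number from compound 2 to compound 4 (0.12 log units; within the scatter) is therefore expected to stay within the scatter, and compound 4 is estimated to give 25 nM (range 8 nM to 80 nM).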

Compound 4, half-maximal inhibitory concentration: 2200 nM
For compound 4 the middle estimate is 88-fold (1.94 log units) below the measured one, and the stated range ends below it.
By their numbers in this assay, from the lowest: compounds 1 and 2 (each within the scatter of the next); then compound 3; then compound 4.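

In this assay, replacing 2-hydroxyethyl with hydrogen gives a 120-fold higher number from compound 2 to compound 4 (2.06 log units; beyond the scatter) and is a large step, so this saturated ring carbon, three ring bonds from the ring nitrogen, matters strongly on the core of compound 2. The earlier measured step concerned only the aromatic part, and it was far smaller than this change from 4-(2-hydroxyethyl)piperidin-1-yl to piperidin-1-yl. Nothing measured here accounts for the size of this step.

Compound 1 and compound 3 carry a methyl on this ring carbon but differ from compound 2 elsewhere as well, so they do not show how a small group behaves on the core of compound 2. Also open, going by these compounds, is whether the step follows the hydroxyl or the carbon chain, and how an ethyl group, a longer chain ending in a hydroxyl, an amine or a carboxylic acid would read at this place.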